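Halogen at the Para Position: From Compound 2 to Compound 3

The source may report more compounds than this note shows. Statements on the series, on what has been measured and on what is new or still open speak of the compounds shown alone.

Measured so far:
- Compound 1, `OC(CCn1nc2c(Br)c(Br)c(Br)c(Br)c2n1)c1ccc(F)cc1`: 116%
- Compound 2, `OC(CCn1nc2c(Br)c(Br)c(Br)c(Br)c2n1)c1ccccc1`: 115%

In a functional assay on MCF7 cells (Homo sapiens) for antiproliferative activity, read by MTT assay, with a stated time of 24 h, tested at 12.5 uM (on this read-out higher numbers stand for a weaker effect at the one concentration tested and lower numbers for a stronger effect), compound 1 gives 116% and compound 2 gives 115%; the two lie within the scatter of each other, so neither can be told apart from the other. The step of a number 1 percentage points lower from compound 1 to compound 2 (within the scatter) shows this. Compound 3, `OC(CCn1nc2c(Br)c(Br)c(Br)c(Br)c2n1)c1ccc(Br)cc1`, differs from compound 2 by bromo in place of hydrogen on an aromatic carbon. Among the compounds with values here, the only step that bears on it, a number 1 percentage points lower from compound 1 to compound 2 (within the scatter), swapped a halogen for hydrogen at the same place without an effect beyond the scatter. For compound 3 the expected step is therefore a number 1 percentage points lower from compound 2 to compound 3 (within the scatter), none beyond the scatter. Compound 3 is estimated at 114%, between 100% and 128%.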

Compound 3, a percentage reported as activity, at one concentration (the size of the read-out at that concentration, not a potency): 82%
Beside the measured number, compound 3's estimate is 32 percentage points above it; the whole stated range lies above it.
By their numbers in this assay, from the lowest: compound 3; then compounds 2 and 1 (each within the scatter of the next).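

On this ring, the place para to a large group responds strongly to bromo: phenyl to 4-bromophenyl gives a number 33 percentage points lower from compound 2 to compound 3 (beyond the scatter), and bromo in place of fluoro gives a number 34 percentage points lower from compound 1 to compound 3 (beyond the scatter). The earlier step therefore does not hold for every halogen here, since the identity of the halogen matters in this assay. Nothing measured here bears on the reason for this.

Still open, from the compounds shown here alone, is whether chloro at this place would behave like fluoro or like bromo. Also open, going by these compounds, is how an amine or a methoxy group there would compare.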